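A few compounds are considered here, and "the series" means these few. Any claim that something is new, unique, unknown or untested is made for them only; others in the source may bear on it.

Within the data shown here, in a physicochemical assay for solubility, read by HPLC, in phosphate buffer, measured as kinetic solubility, with a stated time of 1 h, at pH 7.4, tested at 250 uM (a lower number here means a less soluble compound, a higher number a more soluble compound), three compounds have numbers so far. Compound 1 `CN1CCC(c2ccc3c(c2)oc(=O)n3C(=O)NCCCCc2ccc(F)cc2)CC1` gives 22000 nM, compound 2 `CN1CCC(c2cc3oc(=O)n(C(=O)NCCCCc4ccccc4)c3cc2F)CC1` gives 70000 nM, and compound 3 `CN1CCC(c2ccc3c(c2)oc(=O)n3C(=O)NCCCCc2ccccc2)CC1` gives 120000 nM. Compound 3 stands clear of only one of the other two. The data show a 5.5-fold higher number from compound 1 to compound 3 (0.74 log units; beyond the scatter), a real difference, but also a 1.7-fold higher number from compound 2 to compound 3 (0.23 log units; within the scatter), which is too small to separate the pair.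

Compound 4 `CN1CCC(c2ccc3c(c2)oc(=O)n3C(=O)NCCOCc2ccccc2)CC1` keeps the shared core and alters only the chain: benzyloxy in place of phenethyl on a saturated chain carbon, two bonds along the chain from an amide-type nitrogen. Put simply, it has benzyloxy in place of phenethyl on a saturated chain carbon, two bonds along the chain from an amide-type nitrogen, so 4-phenylbutyl becomes 2-(benzyloxy)ethyl.

Neither measured step touches this chain. Both are hydrogen in place of fluoro on an aromatic carbon, so they offer only a sense of scale for a small edit: one modest, one within the scatter. Among the measured compounds shown here, no measured pair shows what this particular swap does to solubility, so the direction stays open, and the natural starting point is compound 3 at 120000 nM. The expected change is small, with a 1.2-fold higher number from compound 3 to compound 4 (0.07 log units; within the scatter), and no step beyond the scatter is anticipated. For compound 4 the estimated value in this assay is 140000 nM, with an expected range from 60000 nM to 250000 nM.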

Compound 4, solubility: 73000 nM
Estimate against measurement, compound 4: 1.9-fold (0.28 log units) above, within the range that was stated.
By their numbers in this assay, from the lowest: compound 1; then compounds 2, 4 and 3 (each within the scatter of the next).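

Among these compounds, this is the first look at the chain itself rather than the aromatic fluoro: in this assay, benzyloxy in place of phenethyl on a saturated chain carbon, two bonds along the chain from an amide-type nitrogen, gives a 1.6-fold lower number from compound 3 to compound 4 (0.22 log units; within the scatter) and so does not separate the pair, even though the entering group brings one oxygen and one hydrogen-bond acceptor at the same count of heavy atoms. The step that does clear the scatter is a 3.3-fold higher number from compound 1 to compound 4 (0.52 log units; beyond the scatter) for benzyloxy in place of 2-(4-fluorophenyl)ethyl, an edit that swaps the chain and removes the fluoro in one move, so this pair alone cannot divide the gap between those two parts. Nothing among the data at hand explains either number.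

Going by these compounds, one chain swap is a single reading, so it remains open whether other chains at this place would also stay within the scatter of compound 3. A longer chain, an amine in place of the chain oxygen, or a carboxylic acid at the chain end could each test how far this position tolerates change.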